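Swapping Pyrazolyl for Phenyl on the Shared Core

This account rests on a few compounds, and the source may have more. Where it says the series, first, only, none or still open, it means among the compounds named here.

Measured in a functional assay on NCI-H1993 cells (Homo sapiens) for inhibition, read by CCK-8 assay, with a stated time of 72 h; on this read-out higher numbers stand for weaker inhibition and lower numbers for stronger inhibition:
- compound 1 `CC(c1cc2cccnc2cc1F)n1cnc2ncc(-c3cn[nH]c3)nc21`: 187 nM
- compound 2 `CCC(c1cc2cccnc2cc1F)n1cnc2ncc(-c3cn[nH]c3)nc21`: "not determined" (no result reported)
- compound 3 `Oc1nc2ncc(-c3ccccc3)nc2n1Cc1ccc2ncccc2c1`: > 10000 nM, a limit of the assay

Within the data shown here, compound 1 holds the only exact number in this small set, so it is the single firm reference point in this assay. Compound 2 offers no comparison, as no result was reported for it. The value of compound 3 is a limit and not a number, so it cannot give the size of any step.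

The next compound to be tested is compound 4 `CC(c1cc2cccnc2cc1F)n1cnc2ncc(-c3ccccc3)nc21`. It keeps the core of compound 1 but has phenyl in place of 1H-pyrazol-4-yl on an aromatic carbon.

Among the measured compounds shown here, no measured pair isolates this change. Compound 3 also carries phenyl, and it reads > 10000 nM. It differs from compound 1 in other places as well, so it is only a loose guide. Even so, it points toward weaker inhibition, and a move in that direction, beyond the usual scatter, is expected. The expected change is an 8.0-fold higher number from compound 1 to compound 4 (0.90 log units; beyond the scatter).

The estimate for compound 4 is 1500 nM, with an expected range from 250 nM to 9000 nM.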

Compound 4, half-maximal inhibitory concentration: 570 nM
For compound 4 the middle estimate is 2.6-fold (0.42 log units) above the measured one; low and high end bracket the measured number.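

In this assay, among these compounds, this is the first pair that isolates the change on the shared core, and it gives a 3.0-fold higher number from compound 1 to compound 4 (0.48 log units; beyond the scatter), a modest step in the direction of weaker inhibition. Compound 4 carries phenyl, with 0 hydrogen-bond donors and 0 hydrogen-bond acceptors at this aromatic carbon, and still gives 570 nM, so inhibition in this assay does not rest entirely on the 1H-pyrazol-4-yl group. Compound 3 also carries phenyl but differs from compound 4 in other places, so its reading gives no measure of this change, and it is a limit and not a number: the limit of > 10000 nM in this assay, at which 1 of the 4 values shown sits.

The swap changes the ring size, the ring atoms and the counts of donors and acceptors all at once, so the compounds shown cannot say which of these differences accounts for the step. As far as these compounds go, how the position would respond to a phenyl ring carrying an amine or a carboxylic acid, or to a six-membered aromatic ring with a ring nitrogen such as pyridine, remains open.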